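The compounds below may be only part of what the source reports. "The series", "measured", "known", "first", "only" and "open" are said of these compounds alone.

The compounds share one core. Compound 1 `COc1cc2nccc(Oc3ccc4c(NC(=O)c5ccc(C(F)(F)F)cc5)nn(C)c4c3)c2cc1OC` carries a 4-(trifluoromethyl)phenyl on a carbonyl carbon, compound 2 `COc1ccc(NC(=O)Nc2nn(C)c3cc(Oc4ccnc5cc(OC)c(OC)cc45)ccc23)cc1` a (4-methoxyphenyl)carbamoyl on a nitrogen on an aromatic ring, and compound 3 `COc1cccc(Nc2nn(C)c3cc(Oc4ccnc5cc(OC)c(OC)cc45)ccc23)c1` a 3-methoxyphenyl on that same nitrogen. In a functional assay on HUVEC cells (Homo sapiens) for inhibition, with stated times of 2 h and 72 h (a higher number here means a weaker inhibitor, a lower number a stronger inhibitor), compound 1 is reported only as a limit, > 1000 nM. Compound 2 likewise gives no number in this assay but a limit, > 1000 nM. Compound 3 too stands in this assay at a limit rather than a number, > 1000 nM. Everything known here is the limit of > 1000 nM in this assay, at which 3 of the 3 values shown sit.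

Compound 4 `COc1cc2nccc(Oc3ccc4c(NC(=O)c5cccc(C(F)(F)F)c5)nn(C)c4c3)c2cc1OC` differs from compound 3 by (3-(trifluoromethyl)phenyl)carbonyl in place of 3-methoxyphenyl on a nitrogen on an aromatic ring. Within the data shown here, the steps that bear on this are a step that the two limits leave unreadable from compound 1 to compound 3 and a step that the two limits leave unreadable from compound 2 to compound 3, neither of which can be sized. No direction can therefore be read; the closest measured relative is compound 1, and its value is a limit. Compound 4 is expected to show a step that the limit leaves unreadable from compound 3 to compound 4. Compound 4 is estimated at 3000 nM, in a range from 1000 nM to 10000 nM, and is expected most likely to be reported again only as a limit.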

Compound 4, half-maximal inhibitory concentration: > 1000 nM
Compound 4 gave a limit, no number (the forecaster's own chance of this, stated with the estimate: 75%); the middle value is on the limit's open side.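

Among these compounds, compound 4 is again reported only as a limit in this assay, so no step from compound 1, compound 2 or compound 3 to compound 4 can be read. The compounds shown leave open how strongly any of them inhibits and whether any of these changes matters, as all rest on a single limit: the limit of > 1000 nM in this assay, at which 4 of the 4 values shown sit.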